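Ring-substituent changes on the aroyl carbonyl of the shared core

This account rests on a few compounds, and the source may have more. Where it says the series, first, only, none or still open, it means among the compounds named here.

Measured so far:
compound 1, `Cc1c(C(=O)c2ccc(F)c(F)c2)oc2cc(-c3ccccc3)cc(O)c12` — 0.4 ug/mL
compound 2, `Cc1c(C(=O)CCc2ccccc2)oc2cc(-c3ccccc3)cc(O)c12` — > 4 ug/mL
compound 3, `CCc1ccc(C(=O)c2oc3cc(-c4ccccc4)cc(O)c3c2C)cc1` — > 4 ug/mL

In a functional assay on WI-38 VA13 cells (Homo sapiens) for cytotoxicity (on this read-out lower numbers stand for an effect already at smaller amounts and higher numbers for an effect only at larger amounts of compound), compound 1 gives 0.4 ug/mL. For compound 2 the value of > 4 ug/mL is a limit of this assay and not a number. For compound 3 the value of > 4 ug/mL is likewise a limit and not a number. Compound 3 thus stands at the limit, together with one other member of the series (the limit of > 4 ug/mL in this assay, at which 2 of the 3 values shown sit). The steps of an at least 10-fold higher number from compound 1 to compound 2 (1.00 log units; beyond the scatter) and an at least 10-fold higher number from compound 1 to compound 3 (1.00 log units; beyond the scatter) are both beyond the scatter, whereas the step that the two limits leave unreadable from compound 2 to compound 3 cannot be read.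

Compound 4, `Cc1c(C(=O)c2ccc(N(C)C)cc2)oc2cc(-c3ccccc3)cc(O)c12`, differs from compound 3 by dimethylamino in place of ethyl on an aromatic carbon. Within the data shown here, no measured step covers this change; the only steps on the carbonyl substituent lead away from compound 1 towards the limit. Compound 4 is therefore expected to remain near the limit in this assay, with a real chance that only a limit is reported again, giving an expected step of a number no higher from compound 3 to compound 4 (the limit leaves the size open). The estimate for compound 4 is 4 ug/mL, with a range from 1 ug/mL to 10 ug/mL.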

Compound 4, half-maximal effective concentration: > 4 ug/mL
Compound 4 gave a limit, no number; the forecaster's own chance of this, stated with the estimate: 60%; the middle value lies on the limit itself.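

Putting dimethylamino in place of ethyl on this aromatic carbon adds a nitrogen and a hydrogen-bond acceptor, yet in this assay compound 4 gives > 4 ug/mL, which is a limit and not a number. The steps from compound 2 and from compound 3 to compound 4 cannot be read, as limits stand at both ends. The one readable new step is an at least 10-fold higher number from compound 1 to compound 4 (1.00 log units; beyond the scatter), so a third replacement of 3,4-difluorophenyl on the carbonyl carbon now ends at the limit, and compound 1 remains the only compound shown with a number: the limit of > 4 ug/mL in this assay, at which 3 of the 4 values shown sit.

As far as these compounds go, how far compound 2, compound 3 and compound 4 differ from one another remains open. Also open, from the compounds shown here alone, is how a single fluorine on the phenyl ring, or a primary amine or a carboxylic acid in place of dimethylamino, would read in this assay.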